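Phenyl in Place of Propyl at the Limit of Growth Inhibition

A few compounds are considered here, and "the series" means these few. Any claim that something is new, unique, unknown or untested is made for them only; others in the source may bear on it.

Of the compounds shown here, two sharing a common core have been measured in a functional assay on HCT-15 cells (Homo sapiens) for cytotoxicity, read by sulforhodamine B assay, with a stated time of 72 h (on this read-out higher numbers stand for weaker inhibition of growth and lower numbers for stronger inhibition of growth), so far. Compound 1 `CC(=O)N1c2ccccc2CCC1C(=O)Nc1cc(C(F)(F)F)cc(C(F)(F)F)c1` gives > 70000 nM, which is a limit of the assay and not a number. Compound 2 `CCCC(=O)N1c2ccccc2CCC1C(=O)Nc1ccccc1C(F)(F)F` gives > 70000 nM, which is also a limit and not a number. Compound 2 therefore has no exact position on the scale and stands at the limit of > 70000 nM in this assay, at which 2 of the 2 values shown sit.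

Compound 3 `O=C(Nc1ccccc1C(F)(F)F)C1CCc2ccccc2N1C(=O)c1ccccc1` has phenyl in place of propyl on a carbonyl carbon whose other neighbours are: amide-type nitrogen in a ring. The difference is counted as phenyl in place of propyl on a carbonyl carbon, and it also reads as propylcarbonyl to benzoyl.

Among the compounds with values here, no measured step between closely related compounds is available to set the size of this change in this assay. The expected step is therefore none beyond the scatter, with no direction predicted. In numbers, the estimated step of a number no higher from compound 2 to compound 3 (the limit leaves the size open) stays within that scatter. The assay is expected to report only a limit again. Compound 3 is estimated at 70000 nM, with an expected range from 30000 nM to 120000 nM.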

Compound 3, concentration for 50% growth inhibition: 6500 nM
The estimate for compound 3 lay 11-fold (1.03 log units) above the measured number; the measured number lies below the stated range.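

Phenyl in place of propyl on a carbonyl carbon gives an at least 10-fold lower number from compound 2 to compound 3 (1.03 log units; beyond the scatter) in this assay, so this position on the shared core can change the read-out and is not silent, as the earlier compounds alone might have suggested. Among the compounds shown, compound 3 is the only one with a number rather than a limit, at 6500 nM, which gives the series its first fixed point on the scale. The full size of the step stays unknown because the value for compound 2 is a limit and not a number: the limit of > 70000 nM in this assay, at which 2 of the 3 values shown sit.

The pair cannot separate the aromatic ring from the larger count of carbon atoms, since phenyl brings both at once, and a longer chain such as hexyl in the same place would be needed to tell them apart. The compounds shown also leave open how far the number would move with an amine or a carboxylic acid on the benzoyl ring, or whether the same exchange would act alike on the core of compound 1, which carries a different group on its anilide ring.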